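The source may hold more compounds than are shown below. What is called first, only, known or untested is meant among the compounds shown, and "the series" means these compounds.

Measured compounds:
compound 1 `O=C(CCN1C(=O)CSc2ccccc21)N1CCN(c2ccccc2F)CC1`, > 100000 nM
compound 2 `O=C(CCN1C(=O)CSc2ccccc21)N1CCN(c2ccccc2)CC1`, > 100000 nM
compound 3 `O=C(CCN1C(=O)CSc2ccccc21)NCCCN1CCN(c2ccccc2F)CC1`, > 100000 nM

In a functional assay (MiaPaCa cells, Homo sapiens) for inhibition, read by sulforhodamine B assay, with a stated time of 48 h (on this read-out lower numbers stand for stronger inhibition of growth and higher numbers for weaker inhibition of growth), compound 1 gives only a limit, > 100000 nM. Compound 2 likewise gives only a limit in this assay, > 100000 nM. The step that the two limits leave unreadable from compound 1 to compound 2 therefore cannot be read, since (the limit of > 100000 nM in this assay, at which 3 of the 3 values shown sit). The change itself is hydrogen in place of fluoro on an aromatic carbon. Compound 3 also gives only a limit in this assay, > 100000 nM; the difference between its core and that of compound 1 is not broken down here.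

Compound 4 `O=C(CCN1C(=O)CSc2ccccc21)NCCCN1CCN(c2ccccc2)CC1` is not yet measured. It differs from compound 3 by hydrogen in place of fluoro on an aromatic carbon, the same change as from compound 1 to compound 2. Because all three values sit at the limit of > 100000 nM in this assay, at which 3 of the 3 values shown sit, the step that the limit leaves unreadable from compound 3 to compound 4 is expected to leave compound 4 at the limit as well, and its estimate in this assay is 150000 nM.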

Compound 4, concentration for 50% growth inhibition: > 100000 nM
Compound 4 gave a limit, no number; the forecaster's own chance of this, stated with the estimate: 85%; the middle value is on the limit's open side.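

Like compound 3, compound 4 gives only a limit, so no step can be read from compound 3 to compound 4: the limit of > 100000 nM in this assay, at which 4 of the 4 values shown sit. The compounds shown leave open whether swapping 2-fluorophenyl for phenyl changes growth inhibition at all.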